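This account rests on a few compounds, and the source may have more. Where it says the series, first, only, none or still open, it means among the compounds named here.

Measured in a functional assay on MOLT-4 cells (Homo sapiens) for inhibition, with a stated time of 3 days; a higher number here means a weaker inhibitor, a lower number a stronger inhibitor:
- compound 1, `Cc1c(C(=O)/C=C/c2ccc(Cl)cc2)[n+]([O-])c2ccccc2[n+]1[O-]`, gives 7750 nM
- compound 2, `Cc1ccc(/C=C/C(=O)c2c(C)[n+]([O-])c3ccccc3[n+]2[O-])cc1`, gives 8400 nM
- compound 3, `Cc1c(C(=O)/C=C/c2ccc(F)cc2)[n+]([O-])c2ccccc2[n+]1[O-]`, gives 6400 nM

For the measured compounds named here, all three share one core and differ only in the single group on the outer benzene ring. Compound 3 carries the lowest of the three numbers in this assay, but its gap to compound 1, a 1.2-fold lower number from compound 1 to compound 3 (0.08 log units; within the scatter), and its gap to compound 2, a 1.3-fold lower number from compound 2 to compound 3 (0.12 log units; within the scatter), both lie within the scatter, so nothing separates the three. The step from chloro to methyl, a 1.1-fold higher number from compound 1 to compound 2 (0.03 log units; within the scatter), is also within the scatter.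

Compound 4, `Cc1c(C(=O)/C=C/c2ccc(Br)cc2)[n+]([O-])c2ccccc2[n+]1[O-]`, is the next member: bromo in place of fluoro on an aromatic carbon. The three measured swaps of this group, chloro, methyl and fluoro, all left this assay unchanged beyond the scatter, and bromo is a fourth such swap at the same place. A step of no size beyond the scatter is therefore expected, a 1.2-fold higher number from compound 3 to compound 4 (0.07 log units; within the scatter). Compound 4 is estimated at 7500 nM, with a range from 4000 nM to 14000 nM.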

Compound 4, half-maximal inhibitory concentration: 17100 nM
Compound 4: the middle estimate sits 2.3-fold (0.36 log units) below what was measured; measured number above the stated range.
By their numbers in this assay, from the lowest: compounds 3, 1 and 2 (each within the scatter of the next); then compound 4.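

Bromo is the first group at this position whose swap moves the number in this assay beyond the scatter, and it does so against each of the other three groups (a 2.7-fold higher number from compound 3 to compound 4 (0.43 log units; beyond the scatter)) (a 2.0-fold higher number from compound 2 to compound 4 (0.31 log units; beyond the scatter)) (a 2.2-fold higher number from compound 1 to compound 4 (0.34 log units; beyond the scatter)). The position is therefore not indifferent to its group, even though fluoro, chloro and methyl could not be told apart there and all three new steps are only modest. Nothing shown here explains why bromo parts from the other three groups.

On these data alone, whether iodo or methoxy at this position would side with compound 4 or stay with the other three remains open. So does the effect of a group carrying nitrogen, such as an amine, or of moving bromo elsewhere on the ring.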